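A few compounds are considered here, and "the series" means these few. Any claim that something is new, unique, unknown or untested is made for them only; others in the source may bear on it.

In an ADME assay on microsomes from liver (Homo sapiens) for metabolic stability (a lower number here means slower removal, a higher number faster removal of the compound), compound 1 (`CCn1cnc2c(-c3ccc(F)c(-c4cnn(C)c4)c3)cnnc21`) gives 47 mL.min-1.g-1 while compound 2 (`CCn1cnc2c(-c3ccc(F)c(-c4cccnc4)c3)cnnc21`) gives 78 mL.min-1.g-1 and compound 3 (`CCn1cnc2c(-c3ccc(F)c(Oc4ccnc(C)c4)c3)cnnc21`) gives 65 mL.min-1.g-1 on the same core. Compound 3 stands within the scatter of both others, so it cannot be ranked against them. Compound 4 (`CCn1cnc2c(-c3ccc(F)c(OCc4ccccn4)c3)cnnc21`) carries the same atoms as compound 3, with (pyridin-2-yl)methyl in place of 2-methylpyridin-4-yl on an oxygen on an aromatic ring. Within the data shown here, no measured step makes this exact swap. The nearest evidence is that exchanging the group on an aromatic carbon stayed small in all three measured cases (a 1.7-fold higher number from compound 1 to compound 2 (0.22 log units; within the scatter)) and (a 1.4-fold higher number from compound 1 to compound 3 (0.14 log units; within the scatter)) and (a 1.2-fold lower number from compound 2 to compound 3 (0.08 log units; within the scatter)). In this assay a step beyond the scatter is therefore not expected, and neither direction is favoured for the expected step (no change at the digits printed from compound 3 to compound 4 (within the scatter)). For compound 4 the estimated value is 65 mL.min-1.g-1 with an expected range (35 mL.min-1.g-1 to 120 mL.min-1.g-1).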

Compound 4, intrinsic clearance in microsomes: 41 mL.min-1.g-1
Beside the measured number, compound 4's estimate is 1.6-fold (0.20 log units) above it; the range from low to high includes it.
By their numbers in this assay, from the lowest: compounds 4, 1, 3 and 2 (each within the scatter of the next).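

In this assay, joining the same atoms differently, with (pyridin-2-yl)methoxy in place of (2-methylpyridin-4-yl)oxy, gives a 1.6-fold lower number from compound 3 to compound 4 (0.20 log units; within the scatter), so this rearrangement of the group on the oxygen does not change the number measurably. The comparisons with the two compounds whose ring sits directly on the aromatic carbon read the same way, with a 1.9-fold lower number from compound 2 to compound 4 (0.28 log units; within the scatter) and a 1.1-fold lower number from compound 1 to compound 4 (0.06 log units; within the scatter), which leaves all four compounds within the scatter of one another and no group at this position ranked above another. Nothing measured here offers an explanation for these small steps. All the groups shown at this position carry an aromatic ring, and they leave open whether any group here can move the number beyond the scatter. How an amine, a carboxylic acid or a longer chain on the oxygen would behave in this assay remains an open question.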